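Swapping the Aryl Group on a Kinase Inhibitor Core

The source may hold more compounds than are shown below. What is called first, only, known or untested is meant among the compounds shown, and "the series" means these compounds.

compound 1 `CN1C(=O)C(c2cccc(C(F)(F)F)c2)N(C)c2nc(Nc3ccc(S(N)(=O)=O)cc3)ncc21`: 2710 nM
compound 2 `CCc1ccccc1C1C(=O)N(C)c2cnc(Nc3ccc(S(N)(=O)=O)cc3)nc2N1C`: 51 nM
compound 3 `COc1ccccc1C1C(=O)N(C)c2cnc(Nc3ccc(S(N)(=O)=O)cc3)nc2N1C`: 251 nM

Three compounds share one core and differ only in the aromatic group attached to a saturated ring carbon. In an assay on Sf9 cells for inhibition of serine/threonine-protein kinase 4 (Homo sapiens), read by luminescence and ADP-Glo, with a stated time of 1 h, in the presence of a further agent that is not named here (on this read-out higher numbers stand for weaker inhibition and lower numbers for stronger inhibition), compound 1 gives 2710 nM, the highest number of the three, so it is the weakest inhibitor among them. Compound 2 gives 51 nM and compound 3 gives 251 nM. a 53-fold lower number from compound 1 to compound 2 (1.73 log units; beyond the scatter) and an 11-fold lower number from compound 1 to compound 3 (1.03 log units; beyond the scatter); each replacement lowered the number well beyond the scatter. Between those two replacements, a 4.9-fold higher number from compound 2 to compound 3 (0.69 log units; beyond the scatter).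

Compound 4 `CN1C(=O)C(Cc2ccccc2)N(C)c2nc(Nc3ccc(S(N)(=O)=O)cc3)ncc21` has not yet been measured. benzyl in place of 3-(trifluoromethyl)phenyl on a saturated ring carbon Both measured steps from compound 1 removed the same 3-(trifluoromethyl)phenyl group and gave lower numbers, which points toward improvement when that group goes. Yet each of them brought in a phenyl carrying a substituent, whereas benzyl brings an unsubstituted ring on a saturated link, and no measured step tests such a change. The expectation is therefore a lower number than compound 1, but a smaller gain than either measured step: a 3.9-fold lower number from compound 1 to compound 4 (0.59 log units; beyond the scatter) is the step expected. For compound 4 the estimated value is 700 nM, with a range of 120 nM to 4000 nM.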

Compound 4, half-maximal inhibitory concentration: > 10000 nM
Compound 4: no number, only a limit (the forecaster's own chance of this, stated with the estimate: 5%); at least 14-fold (1.15 log units) between middle value and limit.
By their numbers in this assay, from the lowest: compound 2; then compound 3; then compound 1. At a limit, above all of these: compound 4.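

In this assay compound 4 gives > 10000 nM, which is a limit of the assay and not a number. Removing the 3-(trifluoromethyl)phenyl group therefore does not in itself lower the number, since benzyl in its place gives an at least 3.6-fold higher number from compound 1 to compound 4 (0.56 log units; beyond the scatter), the opposite direction from the two earlier replacements, so the gains with compounds 2 and 3 depend on which group enters and not only on which group leaves. The gap to the two substituted phenyl compounds is large, with an at least 39-fold higher number from compound 3 to compound 4 (1.60 log units; beyond the scatter) and an at least 190-fold higher number from compound 2 to compound 4 (2.29 log units; beyond the scatter), so this saturated ring carbon clearly distinguishes benzyl from 2-methoxyphenyl and 2-ethylphenyl.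

As far as these compounds go, the full size of these steps stays open, since all that is known of compound 4 is this: the limit of > 10000 nM in this assay, at which 1 of the 4 values shown sits. Also open is whether the loss follows from the saturated link in benzyl or from its unsubstituted ring, a question that plain phenyl or 2-ethylbenzyl on the same carbon would help to settle, while an amine or a carboxylic acid on the aromatic ring remains untested among the compounds shown.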